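A few compounds are considered here, and "the series" means these few. Any claim that something is new, unique, unknown or untested is made for them only; others in the source may bear on it.

Measured compounds:
Compound 1, `CC(C)c1ccc(-n2nc(-c3ccc(C(F)(F)F)cc3O)nc2-c2ccccc2O)cc1`, in a functional assay on PC-12 cells (Rattus norvegicus) for cytotoxicity, read by MTT assay, with stated times of 2 h and 24 h, tested at 5 uM (a lower number here means a weaker effect, a higher number a stronger effect of the compound at the concentration tested), compound 1 gives 100%.
Compound 2, `Oc1cc(C(F)(F)F)ccc1-c1nc(-c2ccccc2O)n(-c2ccc(Cl)cc2)n1`, in this assay compound 2 gives 87.3%.

Compound 1 stands highest of the two numbers; its nearest neighbour is compound 2, and the step of a number 12.7 percentage points lower from compound 1 to compound 2 (beyond the scatter) is beyond the scatter and modest. Compound 3, `COc1ccccc1-n1nc(-c2ccc(C(F)(F)F)cc2O)nc1-c1ccccc1O`, differs from compound 1 by 2-methoxyphenyl in place of 4-isopropylphenyl on an aromatic nitrogen. Within the data shown here, the one measured step that bears on this change sits at the same aromatic nitrogen, where the step of a number 12.7 percentage points lower from compound 1 to compound 2 (beyond the scatter) was modest. Compound 3 is therefore expected to sit somewhat lower than compound 1 or within the scatter of it, estimated at 88%, between 65% and 100%, a step of a number 12 percentage points lower from compound 1 to compound 3 (beyond the scatter).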

Compound 3, a percentage reported as activity, at one concentration (the size of the read-out at that concentration, not a potency): 85.6%
Compound 3: the middle estimate sits 2.4 percentage points above what was measured, and the stated range covers the measured number.
By their numbers in this assay, from the lowest: compounds 3 and 2 (each within the scatter of the next); then compound 1.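

In this assay, 2-methoxyphenyl in place of 4-isopropylphenyl on the aromatic nitrogen gives a number 14.4 percentage points lower from compound 1 to compound 3 (beyond the scatter), so a second replacement of 4-isopropylphenyl at this position, this one containing oxygen, also brings a modest step down. Set against 4-chlorophenyl, the same group gives a number 1.7 percentage points lower from compound 2 to compound 3 (within the scatter), so the two replacements cannot be told apart here. No measurement shown accounts for these steps.

The compounds shown leave open how 4-methoxyphenyl, with the same group at another ring position, would read in this assay. They also leave open how an aminophenyl or a carboxyphenyl group on this nitrogen would read.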